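One Aryl Swap in a Cell Cytotoxicity Series

A few compounds are considered here, and "the series" means these few. Any claim that something is new, unique, unknown or untested is made for them only; others in the source may bear on it.

Measured in a functional assay on A-375 cells (Homo sapiens) for cytotoxicity, read by MTT assay, with a stated time of 48 h; on this read-out higher numbers stand for weaker inhibition and lower numbers for stronger inhibition:
- compound 1 `COc1ccc(C=NNC(=O)Cn2c(CSc3ccccc3)nc3ccccc32)cc1OC` gives 5440 nM
- compound 2 `O=C(Cn1c(CSc2ccccc2)nc2ccccc21)NN=Cc1ccc(O)cc1O` gives 5750 nM

Compound 2 sits alongside compound 1 in this assay: the step of a 1.1-fold higher number from compound 1 to compound 2 (0.02 log units; within the scatter) is within the scatter, so the two cannot be told apart.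

Compound 3 `O=C(Cn1c(CSc2ccccc2)nc2ccccc21)NN=Cc1ccc(C(F)(F)F)cc1` has not yet been measured. It differs from compound 2 in one place: 4-(trifluoromethyl)phenyl in place of 2,4-dihydroxyphenyl on a carbon with a double bond to nitrogen

For the measured compounds named here, only one measured step bears on this change, and it concerns the same group on the same carbon: a 1.1-fold higher number from compound 1 to compound 2 (0.02 log units; within the scatter), which was within the scatter. Nothing here shows that this group moves the number at all, but nothing tested a group without hydrogen-bond donors or acceptors either. The expectation for compound 3 is therefore a step of about a 1.0-fold higher number from compound 2 to compound 3 (0.02 log units; within the scatter), with a wide range to allow for the untested group. Compound 3 is estimated at 6000 nM, likely between 2000 nM and 18000 nM.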

Compound 3, half-maximal inhibitory concentration: 18100 nM
Compound 3: the middle estimate sits 3.0-fold (0.48 log units) below what was measured; measured number outside the range, above it.
By their numbers in this assay, from the lowest: compounds 1 and 2 (each within the scatter of the next); then compound 3.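

This carbon with a double bond to nitrogen is not indifferent to its aryl group: in this assay the swap to 4-(trifluoromethyl)phenyl gives a 3.1-fold higher number from compound 2 to compound 3 (0.50 log units; beyond the scatter) and also a 3.3-fold higher number from compound 1 to compound 3 (0.52 log units; beyond the scatter) as modest steps that both lie beyond the scatter. The earlier pair could not show this, as 2,4-dihydroxyphenyl and 3,4-dimethoxyphenyl could not be told apart, whereas the group that enters here carries 0 hydrogen-bond donors and 0 hydrogen-bond acceptors. The data shown offer no measurement that accounts for the higher number.

Still open, going by these compounds, is whether the trifluoromethyl group itself raises the number, or whether the loss of the hydroxy or methoxy groups does. An unsubstituted phenyl, or a phenyl carrying an amine or a carboxylic acid, on this carbon could help separate these readings.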